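Methyl in place of chloro on two different cores

The source may hold more compounds than are shown below. What is called first, only, known or untested is meant among the compounds shown, and "the series" means these compounds.

Compound 1 `CC(O)(C(=O)Nc1ccc(S(=O)(=O)c2ccccc2)c(Cl)c1)C(F)(F)F` and compound 2 `Cc1cc(NC(=O)C(C)(O)C(F)(F)F)ccc1S(=O)(=O)c1ccccc1` share one core; compound 3 `CC(O)(C(=O)Nc1ccc(C(=O)c2cccc(Cl)c2)cc1)C(F)(F)F` and compound 4 `Cc1cccc(C(=O)c2ccc(NC(=O)C(C)(O)C(F)(F)F)cc2)c1` share another, and the difference between the two cores is not broken down here. In a functional assay (Cavia porcellus) with sulfonylurea receptors; K-ATP channels (Homo sapiens) as the target (a higher number here means a weaker inhibitor, a lower number a stronger inhibitor), compound 1 gives 2200 nM. In this assay compound 2 gives 1600 nM. The change methyl in place of chloro on an aromatic carbon produced a 1.4-fold lower number from compound 1 to compound 2 (0.14 log units; within the scatter). For compound 3 in this assay only a limit is known, namely > 30000 nM. That value is the limit of > 30000 nM in this assay, at which 1 of the 3 values shown sits. The change to compound 4, (methyl in place of chloro on an aromatic carbon), is the same kind of change, though the earlier place was also ortho to a group of 9 heavy atoms, which the place in compound 3 is not. Because the earlier step was a 1.4-fold lower number from compound 1 to compound 2 (0.14 log units; within the scatter), compound 4 is expected to show a step of about a number no higher from compound 3 to compound 4 (the limit leaves the size open). Compound 4 is therefore estimated at 30000 nM, within 10000 nM to 100000 nM, most likely again as a limit.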

Compound 4, half-maximal inhibitory concentration: > 30000 nM
Compound 4: no number, only a limit; the forecaster's own chance of this, stated with the estimate: 75%; the middle value sits exactly at the limit.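

Compound 3 and compound 4 both stand only as limits in this assay, so no step between them can be read: the limit of > 30000 nM in this assay, at which 2 of the 4 values shown sit.

The compounds shown leave open what methyl in place of chloro does on the core of compound 3.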